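This account rests on a few compounds, and the source may have more. Where it says the series, first, only, none or still open, it means among the compounds named here.

Measured so far, in an assay on membranes from brain for displacement of a labelled ligand from Sigma non-opioid intracellular receptor 1 (Cavia porcellus), read by scintillation counting, with a stated time of 120 min; a higher number here means a weaker inhibitor, a lower number a stronger inhibitor:
- compound 1 `Cc1cccc2sc(NC(=O)CCN3CCN(C(C)C)CC3)nc12` gives 1300 nM
- compound 2 `Cc1cccc2sc(NC(=O)CCN3CCN(C(C)(C)C)CC3)nc12` gives 147 nM
- compound 3 `CCCCCCN1CCN(CCC(=O)Nc2nc3c(C)cccc3s2)CC1` gives 238 nM

All three share one core and differ only in the group carried by the amine nitrogen in the ring. Compound 1 has the highest number of the three, so it is the weakest inhibitor here. Turning its isopropyl into tert-butyl gave an 8.8-fold lower number from compound 1 to compound 2 (0.95 log units; beyond the scatter), and replacing the isopropyl with hexyl gave a 5.5-fold lower number from compound 1 to compound 3 (0.74 log units; beyond the scatter); compounds 2 and 3 differ from each other by a 1.6-fold higher number from compound 2 to compound 3 (0.21 log units; within the scatter).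

Compound 4 `Cc1cccc2sc(NC(=O)CCN3CCN(CCN(C(C)C)C(C)C)CC3)nc12` has not yet been measured. Compared with compound 1 the change is 2-(diisopropylamino)ethyl in place of isopropyl on an amine nitrogen in a ring. The two measured steps that start from compound 1 both bear on this: each swaps the isopropyl on that ring nitrogen for a different group, and each lowered the number well beyond the scatter. A modest lowering in this assay is therefore expected for compound 4, though the group entering here is unlike tert-butyl or hexyl, so the size is uncertain. Compound 4 is estimated at 300 nM, within 90 nM to 1000 nM, which is expected to amount to a 4.3-fold lower number from compound 1 to compound 4 (0.64 log units; beyond the scatter).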

Compound 4, inhibition constant: 809 nM
Beside the measured number, compound 4's estimate is 2.7-fold (0.43 log units) below it, and the stated range covers the measured number.
By their numbers in this assay, from the lowest: compounds 2 and 3 (each within the scatter of the next); then compounds 4 and 1 (each within the scatter of the next).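

In this assay, replacing the isopropyl on this amine nitrogen in a ring does not always give a clear shift: a 1.6-fold lower number from compound 1 to compound 4 (0.21 log units; within the scatter) is a step within the usual scatter, so these two compounds cannot be told apart even though 2-(diisopropylamino)ethyl is a much larger group than isopropyl. The other two comparisons do separate, and the step of a 5.5-fold higher number from compound 2 to compound 4 (0.74 log units; beyond the scatter) along with the step of a 3.4-fold higher number from compound 3 to compound 4 (0.53 log units; beyond the scatter) both lie beyond the scatter; the second of these is the sharper test, since it keeps the saturated chain carbons nearest the ring nitrogen and swaps only the butyl part of hexyl for diisopropylamino. Among these four compounds, then, a larger group at this position does not by itself go with a lower number, and nothing available here explains the difference between the diisopropylamino end and the butyl end.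

On these data alone, what remains open is whether the nitrogen in the new group or the two isopropyl groups on it account for the step from compound 3, which a dimethylamino group on the same ethyl link could help separate. As far as these compounds go, it is also open how a chain ending in a hydroxyl or a piperidine ring would read at this position.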